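The source may report more compounds than this note shows. Statements on the series, on what has been measured and on what is new or still open speak of the compounds shown alone.

Measured so far:
compound 1 `COc1cc(C(=O)N2CCC(O)CC2)cc2nc(NCc3cccc(Cl)c3)oc12` — 21.7 mL/min/kg
compound 2 `COc1cc(C(=O)N2CC[C@H](O)[C@@H](C)C2)cc2nc(NCc3cccc(Cl)c3)oc12` — 36.7 mL/min/kg

In an ADME assay on cells (Hepatocyte, Rattus norvegicus, strain Wistar) for pharmacokinetics, read by LC-MS, with a stated time of 90 min, tested at 1 uM (on this read-out lower numbers stand for slow clearance and higher numbers for fast clearance), compound 1 holds the lowest of the two numbers; the nearest is compound 2, reached by a 1.7-fold higher number from compound 1 to compound 2 (0.23 log units; within the scatter).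

Compound 3 `CCC1CC(O)C(C)CN1C(=O)c1cc(OC)c2oc(NCc3cccc(Cl)c3)nc2c1` is not yet measured. It differs from compound 1 by 2-ethyl-4-hydroxy-5-methylpiperidin-1-yl in place of 4-hydroxypiperidin-1-yl on a carbonyl carbon. Within the data shown here, the single step with any bearing is a 1.7-fold higher number from compound 1 to compound 2 (0.23 log units; within the scatter), where the change is a methyl on a saturated ring carbon and the number stays within the scatter. Among the measured compounds shown here, compound 3 carries the 2-ethyl-4-hydroxy-5-methylpiperidin-1-yl group, with more carbon than compound 2 adds, so a further upward step is expected, though only one comparison supports it. The expected step from compound 1 is a 2.1-fold higher number from compound 1 to compound 3 (0.32 log units; beyond the scatter), a modest rise that may sit at the edge of the scatter. The estimate for compound 3 in this assay is 45 mL/min/kg, with a range from 22 mL/min/kg to 90 mL/min/kg.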

Compound 3, clearance: 61.7 mL/min/kg
Estimate against measurement, compound 3: 1.4-fold (0.14 log units) below; low and high end bracket the measured number.
By their numbers in this assay, from the lowest: compounds 1, 2 and 3 (each within the scatter of the next, the first and the last beyond it).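

In this assay, among these compounds, the 2-ethyl-4-hydroxy-5-methylpiperidin-1-yl group on the carbonyl carbon gives a 2.8-fold higher number from compound 1 to compound 3 (0.45 log units; beyond the scatter), the first step to lie beyond the scatter. Against the 4-hydroxy-3-methylpiperidin-1-yl group of compound 2, the same group gives a 1.7-fold higher number from compound 2 to compound 3 (0.23 log units; within the scatter), which stays within the scatter, so only compound 1 and compound 3 stand apart on this read-out, while compound 2 cannot be separated from either. No measurement at hand accounts for the gap between compound 1 and compound 3.

From the compounds shown here alone, whether the ethyl alone, without the methyl, would give a step of this size remains open, as does the influence of the undefined stereochemistry of compound 3. Also open, going by these compounds, is how an amine or a carboxylic acid in place of the ethyl would read in this assay on the same core.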